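Chloro in Place of Trifluoromethyl: Expecting Compound 3

The source may report more compounds than this note shows. Statements on the series, on what has been measured and on what is new or still open speak of the compounds shown alone.

Compound 1, `COc1cc2cc(Oc3ccc(NC(=O)Nc4cccc(C(F)(F)F)c4)cc3)c(C)nc2cc1OC`, in a functional assay on SK-OV-3 cells (Homo sapiens) for inhibition, read by sulforhodamine B assay, with a stated time of 48 h (on this read-out higher numbers stand for lower toxicity in this test and lower numbers for higher toxicity in this test), reaches only the limit > 50000 nM. Compound 2, `COc1cc2cc(Oc3ccc(NC(=O)Nc4ccc(Cl)c(C(F)(F)F)c4)cc3)c(C)nc2cc1OC`, in this assay gives 31500 nM.

For the measured compounds named here, compound 2 holds the only number; the other value is a limit (the limit of > 50000 nM in this assay, at which 1 of the 2 values shown sits). Going by the values given here, the one measured step, an at least 1.5-fold lower number from compound 1 to compound 2 (0.20 log units; that floor lies within the scatter), concerns a different exchange. Compound 3, `COc1cc2cc(Oc3ccc(NC(=O)Nc4ccc(Cl)c(Cl)c4)cc3)c(C)nc2cc1OC`, differs from compound 2 by chloro in place of trifluoromethyl on an aromatic carbon. Among the compounds with values here, no measured step swaps these two groups, so no shift beyond the scatter is expected in this assay. Compound 3 is therefore estimated at 30000 nM, between 10000 nM and 60000 nM, meaning a 1.1-fold lower number from compound 2 to compound 3 (0.02 log units; within the scatter).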

Compound 3, concentration lethal to 50% of the cells: 84800 nM
Estimate against measurement, compound 3: 2.8-fold (0.45 log units) below; the measured number lies above the stated range.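

In this assay, this position proves sensitive to the exchange: chloro in place of trifluoromethyl, ortho to a chloro group, gives a 2.7-fold higher number from compound 2 to compound 3 (0.43 log units; beyond the scatter). This is the only readable step shown that lies beyond the scatter, and here the higher number means lower toxicity in this test. Compound 1 stands at a limit, so its step to compound 3 cannot be read: the limit of > 50000 nM in this assay, at which 1 of the 3 values shown sits.

As far as these compounds go, how a methoxy group, a nitrile or an amine would read at this position remains open. So does whether the same exchange would shift the number similarly in a compound lacking the other chloro group.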